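The source may report more compounds than this note shows. Statements on the series, on what has been measured and on what is new or still open speak of the compounds shown alone.

Measured compounds:
compound 1 `Nc1nc(Cl)c2ncn(Cc3ccc(CCl)cc3)c2n1`: 22900 nM
compound 2 `ClCc1cccc(Cn2cnc3c(Cl)nc(Cl)nc32)c1`: 3800 nM
compound 3 `ClCc1ccc(Cn2cnc3c(Cl)nc(Cl)nc32)cc1`: 3240 nM

All three numbers come from a functional assay on KM12 cells (Homo sapiens) for cytotoxicity, read by sulforhodamine B assay, with a stated time of 48 h; a higher number here means a weaker inhibitor of growth, a lower number a stronger inhibitor of growth. Compound 2 and compound 3 are built from the same atoms joined differently; the difference between the two cores is not broken down here, and their two values lie within the usual scatter of each other.

Compound 4 `Nc1nc(Cl)c2ncn(Cc3cccc(CCl)c3)c2n1` has not yet been measured. It differs from compound 2 by amino in place of chloro on an aromatic carbon. The same change, at the same place, separates compound 3 from compound 1: amino in place of chloro on an aromatic carbon. That measured step gave a 7.1-fold higher number from compound 3 to compound 1 (0.85 log units; beyond the scatter).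

Going by the values given here, a step of similar size is expected from compound 2 to compound 4, a 7.1-fold higher number from compound 2 to compound 4 (0.85 log units; beyond the scatter), resting on the single measured example of this change in this assay.

In this assay compound 4 is expected to give 27000 nM, with a likely range from 9000 nM to 80000 nM.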

Compound 4, concentration for total growth inhibition: 13200 nM
Estimate against measurement, compound 4: 2.0-fold (0.31 log units) above, within the range that was stated.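

In this assay, amino in place of chloro on an aromatic carbon gives a 3.5-fold higher number from compound 2 to compound 4 (0.54 log units; beyond the scatter), so the number rises on this core as well. Set beside the earlier step, the change carries over in direction and, within the scatter, in size: the same change on two cores in this assay, a 7.1-fold higher number (0.85 log units; beyond the scatter) from compound 3 to compound 1 and a 3.5-fold higher number (0.54 log units; beyond the scatter) from compound 2 to compound 4, 2.0-fold (0.31 log units) apart, within the scatter of two such steps. Going by these compounds alone, these are only two pairs in a single cell assay, which does not show that the step would hold on a more distant core or in other cells, and does not explain why the number rises.

The compounds shown leave open how a methoxy or dimethylamino group would behave at the same carbon. Also open, on these data alone, is whether the numbers depend on the chloromethyl group, which a methyl or hydroxymethyl group in its place would test.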